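The source may hold more compounds than are shown below. What is called first, only, known or untested is meant among the compounds shown, and "the series" means these compounds.

Measured so far:
compound 1 `CCO[C@H]1C[C@@H](c2coc3ccc(Br)cc3c2=O)N(c2ccccc2)O1` — > 60000 nM
compound 2 `NC(=O)[C@H]1C[C@@H](c2coc3ccccc3c2=O)N(c2ccccc2)O1` — > 60000 nM
compound 3 `CCO[C@H]1C[C@@H](c2coc3ccc(C)cc3c2=O)N(c2ccccc2)O1` — 39000 nM

In a functional assay on PC-3 cells (Homo sapiens) for inhibition, read by sulforhodamine B assay, with a stated time of 48 h (a lower number here means a stronger inhibitor, a higher number a weaker inhibitor), the two values with a sign are limits of the assay, not numbers. From the compounds shown here alone, compound 2 stands at the limit of > 60000 nM in this assay, at which 2 of the 3 values shown sit, so its true value is unknown beyond that boundary. Within the data shown here, the only measured step, an at least 1.5-fold lower number from compound 1 to compound 3 (0.18 log units; that floor lies within the scatter), concerns the aromatic ring and does not touch the saturated ring carbon, so it does not bear directly on the present change.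

Compound 4 `O=c1c([C@@H]2C[C@H](c3ccncc3)ON2c2ccccc2)coc2ccccc12` differs from compound 2 by pyridin-4-yl in place of carbamoyl on a saturated ring carbon. Among the measured compounds shown here, no measured step informs this change; the series as a whole sits at or near the weak end of the assay.

Compound 4 is therefore expected near 45000 nM, within 12000 nM to 150000 nM, which would mean an expected step of an at least 1.3-fold lower number from compound 2 to compound 4 (0.12 log units; that floor lies within the scatter).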

Compound 4, half-maximal inhibitory concentration: 46000 nM
Beside the measured number, compound 4's estimate is 1.0-fold (0.01 log units) below it; measured number inside the range.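

In this assay, the saturated ring carbon next to the ring oxygen carries pyridin-4-yl and still gives a reading rather than a limit, the first view of an aromatic ring at this position. The change from carbamoyl is an at least 1.3-fold lower number from compound 2 to compound 4 (0.11 log units; that floor lies within the scatter). Compound 2 rests on a limit of the assay, so only a floor can be read for this step: the limit of > 60000 nM in this assay, at which 2 of the 4 values shown sit.

Open, from the compounds shown here alone, is how an amine or a carboxylic acid on this carbon would read. Also open, going by these compounds, is whether pyridin-4-yl combines with the aromatic methyl of compound 3.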